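The compounds below may be only part of what the source reports. "The series", "measured", "known", "first", "only" and "open" are said of these compounds alone.

In a functional assay on HeLa cells (Homo sapiens) for inhibition, read by MTT assay, with a stated time of 72 h (a lower number here means a stronger inhibitor, a higher number a weaker inhibitor), compound 1 `Cc1ccc2nc(-c3ccc(NCc4cn(Cc5cc(=O)oc6cc(O)ccc56)nn4)cc3)sc2c1` gives 7260 nM. Compound 2 `Cc1ccc2c(Cn3cc(CNc4ccc(-c5nc6ccc(C)cc6s5)cc4)nn3)cc(=O)oc2c1` differs from it by one change, (methyl in place of hydroxy on an aromatic carbon), and in this assay compound 2 gives 51400 nM; the step is a 7.1-fold higher number from compound 1 to compound 2 (0.85 log units; beyond the scatter). Compound 3 `O=c1cc(Cn2cc(-n3ccc4cc(I)ccc43)nn2)c2ccc(O)cc2o1` rests on a different core, and the difference between the two cores is not broken down here; in this assay compound 3 gives 14200 nM, which sits within the scatter of the number for compound 1 and beyond it from the number for compound 2. Compound 4 `Cc1ccc2c(Cn3cc(-n4ccc5cc(I)ccc54)nn3)cc(=O)oc2c1` is not yet measured. It differs from compound 3 by methyl in place of hydroxy on an aromatic carbon, the same change that turned compound 1 into compound 2, at a place described in the same words. Going by the values given here, only that single pair shows the change, so the expectation for compound 4 rests on it alone, on the number for compound 3, and on the weakening seen in a 7.1-fold higher number from compound 1 to compound 2 (0.85 log units; beyond the scatter). The step from compound 3 to compound 4 is therefore expected to be a 5.3-fold higher number from compound 3 to compound 4 (0.72 log units; beyond the scatter). In this assay compound 4 is estimated at 75000 nM, with a likely span from 25000 nM to 220000 nM.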

Compound 4, half-maximal inhibitory concentration: 34400 nM
Compound 4: the middle estimate sits 2.2-fold (0.34 log units) above what was measured, within the range that was stated.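

In this assay, methyl in place of hydroxy on an aromatic carbon again weakens the compound, with a 2.4-fold higher number from compound 3 to compound 4 (0.38 log units; beyond the scatter), so the direction of the change carries over from the core of compound 1 to the core of compound 3. The size of the change does not carry over, and the two steps differ by more than the usual scatter allows: the same change on two cores in this assay, a 7.1-fold higher number (0.85 log units; beyond the scatter) from compound 1 to compound 2 and a 2.4-fold higher number (0.38 log units; beyond the scatter) from compound 3 to compound 4, 2.9-fold (0.47 log units) apart, beyond the scatter of two such steps. This shows that, on these two cores, the change keeps its direction while a step read on one core cannot be applied at full size to the other; it does not show why the size differs, and two pairs set no rule for any further core.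

The compounds shown leave open what an amine or a methoxy group would give on this aromatic carbon on either core, and whether such a group would stand nearer to hydroxy or to methyl. They also leave open how the same change would behave on a core other than these two.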